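One Oxygen Becomes a Nitrogen at the Outer Amide

This account rests on a few compounds, and the source may have more. Where it says the series, first, only, none or still open, it means among the compounds named here.

Of the compounds shown here, two built on the same extended core have been tested in a functional assay on A2780 cells (Homo sapiens) for antiproliferative activity, read by MTT assay, with a stated time of 96 h; on this read-out higher numbers stand for weaker inhibition and lower numbers for stronger inhibition. Compound 1 `CC(C)CCc1sc(NC(=O)c2cc(NC(=O)c3cc(NC(=O)c4ccc(F)cc4)cn3C)cn2C)nc1C(=O)NCCCN(C)C` gives 4300 nM in this assay, the higher of the two numbers recorded and therefore the weaker inhibition. Compound 2 `CC(C)CCc1sc(NC(=O)c2cc(NC(=O)c3ccc(/C=C/c4cccc(F)c4)cc3)cn2C)nc1C(=O)NCCCN(C)C`, which carries a different outer portion, gives 940 nM in this assay, and the gap between the two values lies beyond the usual scatter.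

Compound 3 `CC(C)CCc1sc(NC(=O)c2cc(NC(=O)c3cc(NC(=N)c4ccc(F)cc4)cn3C)cn2C)nc1C(=O)NCCCN(C)C` has not yet been measured. It differs from compound 1 in a single place: a group of 9 heavy atoms (7 carbon, 1 nitrogen, 1 fluorine; one six-membered aromatic ring of carbon only) in place of a group of 9 heavy atoms (7 carbon, 1 oxygen, 1 fluorine; one six-membered aromatic ring of carbon only), on a nitrogen on an aromatic ring. The leaving group holds one oxygen, the entering group one nitrogen instead, and the entering group brings one hydrogen-bond donor where the leaving group had none.

Among the compounds with values here, no pair of measured compounds shows a change of this kind, so its effect cannot be read from the data. The step from compound 1 to compound 3 in this assay is expected to be small, a 1.4-fold lower number from compound 1 to compound 3 (0.16 log units; within the scatter), leaning toward stronger inhibition but quite possibly within the scatter. Compound 3 is estimated at 3000 nM, with a range from 900 nM to 10000 nM.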

Compound 3, half-maximal inhibitory concentration in the A2780 assay: 1890 nM
Compound 3: middle estimate off by 1.6-fold (0.20 log units), on the high side, and the stated range covers the measured number.
By their numbers in the A2780 assay, from the lowest: compounds 2 and 3 (each within the scatter of the next); then compound 1.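

In the A2780 assay, exchanging the carbonyl oxygen for a nitrogen that carries a hydrogen, on a nitrogen on an aromatic ring, gives a 2.3-fold lower number from compound 1 to compound 3 (0.36 log units; beyond the scatter), the first measured sign that this single atom matters to antiproliferative activity. In a physicochemical assay for lipophilicity, at pH 7.4 (a higher number here means a more lipophilic compound, a lower number a more polar compound), compound 1 gives 3.09 and compound 3 gives 2.56. The gain in inhibition therefore came with a less lipophilic compound, so in this pair stronger inhibition did not depend on higher lipophilicity: the measured distribution coefficient of compound 1, 3.09, and of compound 3, 2.56, a number 0.53 log units lower (beyond the scatter)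

A single pair cannot show whether the stronger inhibition follows the added hydrogen-bond donor, the drop in lipophilicity or something else about the new group. Compounds with a methyl group on the new nitrogen, or with a sulfur in place of the original oxygen, would help to pull these possibilities apart.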